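The compounds below may be only part of what the source reports. "The series", "measured", "known", "first", "only" and "open" are said of these compounds alone.

Of the compounds shown here, three built on the same core have been measured in an assay on MDA-MB-231 cells for binding affinity to C-X-C chemokine receptor type 4 (Homo sapiens), read by immunofluorescence and microscopy, with stated times of 10 min and 30 min; on this read-out higher numbers stand for an effect only at larger amounts of compound and lower numbers for an effect already at smaller amounts. Compound 1 `O=C(NCc1ccc(CNS(=O)(=O)c2ccccc2)cc1)c1ccccc1Cl` gives 10 nM in this assay. Compound 2 `COc1ccccc1C(=O)NCc1ccc(CNS(=O)(=O)c2ccccc2)cc1` gives 1 nM, and compound 3 `O=C(NCc1ccc(CNS(=O)(=O)c2ccccc2)cc1)c1ccc(F)cc1` gives 100 nM. Compound 3 thus stands at the highest number of the three, its effect appearing only at the largest amount of compound: the step of a 10-fold higher number from compound 1 to compound 3 (1.00 log units; beyond the scatter) and the step of a 100-fold higher number from compound 2 to compound 3 (2.00 log units; beyond the scatter) both lie beyond the scatter.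

Compound 4 `COc1cccc(C(=O)NCc2ccc(CNS(=O)(=O)c3ccccc3)cc2)c1` has not yet been measured. It differs from compound 3 in one place: 3-methoxyphenyl in place of 4-fluorophenyl on a carbonyl carbon. Among the compounds with values here, two measured steps bear on this. The step of a 100-fold higher number from compound 2 to compound 3 (2.00 log units; beyond the scatter) shows that trading a methoxy-bearing ring for the 4-fluorophenyl raised the number strongly, and the step of a 10-fold lower number from compound 1 to compound 2 (1.00 log units; beyond the scatter) shows that methoxy in place of chloro lowered it. Both point toward a lower number when a methoxyphenyl returns, yet compound 4 carries a 3-methoxyphenyl rather than the 2-methoxyphenyl of compound 2, so the full gain seen for compound 2 cannot be assumed. A step downward beyond the scatter is expected, of middling size.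

Compound 4 is therefore expected to give about 15 nM in this assay, most likely between 2 nM and 150 nM. That estimate corresponds to an expected step of a 6.7-fold lower number from compound 3 to compound 4 (0.82 log units; beyond the scatter).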

Compound 4, effective concentration (reported as EC, without a stated level of effect): > 1000 nM
Compound 4 gave a limit, no number; the forecaster's own chance of this, stated with the estimate: 5%; middle value at least 66-fold (1.82 log units) away from the limit.
By their numbers in this assay, from the lowest: compound 2; then compound 1; then compound 3. At a limit, above all of these: compound 4.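

In this assay compound 4 stands at a limit of the assay and not at a number: the limit of > 1000 nM in this assay, at which 1 of the 4 values shown sits. The earlier compounds shown here suggested that a methoxy-bearing ring on this carbonyl carbon favoured a low number, but compound 4 shows that this does not hold for every methoxyphenyl group: with 3-methoxyphenyl in place of 2-methoxyphenyl, the result is an at least 1000-fold higher number from compound 2 to compound 4 (3.00 log units; beyond the scatter). So at this position the exact group matters, not just the presence of a methoxy, and 3-methoxyphenyl also compares poorly with both non-methoxy groups, giving an at least 10-fold higher number from compound 3 to compound 4 (1.00 log units; beyond the scatter) and an at least 100-fold higher number from compound 1 to compound 4 (2.00 log units; beyond the scatter), which makes compound 4 the exception to the earlier trend rather than a moderate improvement on compound 3.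

Going by these compounds, since compound 4 has only a limit, the true size of these steps remains unknown beyond the minimum each one states. It also remains open whether a hydroxy group or an amine in place of the methoxy of compound 2 would keep a number as low as that of compound 2, and the compounds shown do not explain why the two methoxyphenyl groups differ so sharply.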